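The source may hold more compounds than are shown below. What is called first, only, known or untested is meant among the compounds shown, and "the series" means these compounds.

Compound 1 `COc1cccc(OC)c1C(=O)Nc1c[nH]nc1C(=O)NC1CCCCCC1` and compound 2 `CO[C@H]1CC[C@H](NC(=O)c2n[nH]cc2NC(=O)c2ncoc2-c2ccccc2)CC1` are the two measured compounds here. In an ADME assay on MRC5 cells (Homo sapiens) for inhibition, with a stated time of 72 h (a higher number here means that more compound is needed for the effect, a lower number that less compound is needed), compound 1 gives 42000 nM, the higher of the two numbers, while compound 2 gives 28000 nM; the gap between them lies within the usual scatter, so neither stands apart. Compound 3 `COc1cccc(OC)c1C(=O)Nc1c[nH]nc1C(=O)NCCCOC(C)C` is not yet measured. It differs from compound 1 in one place: 3-isopropoxypropyl in place of cycloheptyl on an amide-type nitrogen. Within the data shown here, with no measured step of this kind to draw on, the step from compound 1 to compound 3 is expected to be small, at most a modest rise, a 1.2-fold higher number from compound 1 to compound 3 (0.08 log units; within the scatter). Compound 3 is therefore estimated at 50000 nM, with a range from 20000 nM to 120000 nM.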

Compound 3, half-maximal effective concentration: > 50000 nM
Compound 3 ended at the assay's limit; the forecaster's own chance of this, stated with the estimate: 30%; the middle value sits exactly at the limit.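

At the amide-type nitrogen, 3-isopropoxypropyl in place of cycloheptyl gives, in this assay, an at least 1.1-fold higher number from compound 1 to compound 3 (0.07 log units; that floor lies within the scatter). This first step read at this position shows that a chain with no ring does not bring the number down. For compound 3, > 50000 nM is a limit of the assay and not a number, so the full size of the step stays unknown: the limit of > 50000 nM in this assay, at which 1 of the 3 values shown sits.

The compounds shown leave open whether an amine, a carboxylic acid or a longer chain on this nitrogen would give a number clear of the limit.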